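Ring-amine aryl exchange in the chroman series

This account rests on a few compounds, and the source may have more. Where it says the series, first, only, none or still open, it means among the compounds named here.

Compound 3 `COc1ccccc1N1CCN(CC2(C)CCc3c(C)c(O)c(C)c(C)c3O2)CC1` sits at 1000 nM in a functional assay (brain) for inhibition, with Rattus norvegicus as the target (on this read-out higher numbers stand for weaker inhibition and lower numbers for stronger inhibition), level with compound 1 `Cc1c(C)c2c(c(C)c1O)CCC(C)(C(=O)N1CCN(c3ccccn3)CC1)O2` at 1000 nM; together these are the highest of the three numbers, while compound 2 `Cc1c(C)c2c(c(C)c1O)CCC(C)(C(=O)N1CCN(c3ccc(Cl)cc3)CC1)O2` at 800 nM lies nearest in this assay below them, the gap being within the scatter. Compound 4 `Cc1c(C)c2c(c(C)c1O)CCC(C)(CN1CCN(c3ccc(Cl)cc3)CC1)O2` is not yet measured and differs from compound 3 by 4-chlorophenyl in place of 2-methoxyphenyl on an amine nitrogen in a ring.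

For the measured compounds named here, only one measured step involves the entering group: a 1.3-fold lower number from compound 1 to compound 2 (0.10 log units; within the scatter). That step replaces a different group than the one leaving here, and its two compounds carry a linker unlike that of compound 3 and compound 4, so it speaks to the entering 4-chlorophenyl only, not to the loss of 2-methoxyphenyl. Going by the values given here, no measured pair shows 2-methoxyphenyl against any other group on the same core as compound 3. Across all three numbers the aryl on the ring nitrogen moves this assay by nothing beyond the scatter, so the expected step to compound 4 is a 1.2-fold lower number from compound 3 to compound 4 (0.07 log units; within the scatter), no real shift.

For compound 4 in this assay the estimate is 850 nM, with a range from 400 nM to 1800 nM.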

Compound 4, half-maximal inhibitory concentration: 900 nM
Compound 4: the middle estimate sits 1.1-fold (0.02 log units) below what was measured; the range from low to high includes it.
By their numbers in this assay, from the lowest: compounds 2, 4, 1 and 3 (each within the scatter of the next).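

In this assay, for the compounds shown here, the change on the amine nitrogen in the ring now has a reading on the core of compound 3, where a 1.1-fold lower number from compound 3 to compound 4 (0.05 log units; within the scatter) is the only measured aryl exchange. The exchange removes 2-methoxyphenyl, with 1 hydrogen-bond acceptor, and brings in 4-chlorophenyl, with 0 hydrogen-bond acceptors, and the read-out stays within the scatter; with a 1.3-fold lower number from compound 1 to compound 2 (0.10 log units; within the scatter) on the core of compound 1, both measured aryl exchanges in these four compounds now lie within the scatter, on two different linkers, and neither goes against the other. No measurement shown accounts for this flat response, and none bears on what lies behind it.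

The compounds shown leave open whether a group of another kind on that ring nitrogen, such as a plain methyl or a benzyl, would give a step beyond the scatter, since all four carry an aromatic ring directly on it. They also leave open whether a carboxylic acid or an amine on the aryl ring would move this read-out, as the substituents seen so far are limited to methoxy and chloro.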